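Swapping the Difluorophenyl Amide for a Methylphenyl Amide

This account rests on a few compounds, and the source may have more. Where it says the series, first, only, none or still open, it means among the compounds named here.

Three measured compounds share one core and differ only in the aryl group on the amide carbonyl carbon. Compound 1 `COc1ccc(C(=O)Nc2cccc(-c3oc4cc(-c5ccc(F)cc5)ccc4c(=O)c3O)c2)cc1` carries a 4-methoxyphenyl and gives 8420 nM in a functional assay on HepG2 cells (Homo sapiens) for antiproliferative activity, read by CCK-8 assay, with a stated time of 72 h; a lower number here means a stronger inhibitor, a higher number a weaker inhibitor. Compound 2 `Cc1ccc(C(=O)Nc2cccc(-c3oc4cc(-c5ccc(F)cc5)ccc4c(=O)c3O)c2)cc1` carries a 4-methylphenyl and gives 2320 nM in this assay. Compound 3 `O=C(Nc1cccc(-c2oc3cc(-c4ccc(F)cc4)ccc3c(=O)c2O)c1)c1ccc(F)cc1F` carries a 2,4-difluorophenyl and gives 26400 nM in this assay, the highest number of the three; compound 1 lies nearest and compound 2 furthest, as a 3.1-fold higher number from compound 1 to compound 3 (0.50 log units; beyond the scatter) and an 11-fold higher number from compound 2 to compound 3 (1.06 log units; beyond the scatter) show.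

Compound 4 `Cc1cccc(C(=O)Nc2cccc(-c3oc4cc(-c5ccc(F)cc5)ccc4c(=O)c3O)c2)c1` is not yet measured. The change from compound 3 is 3-methylphenyl in place of 2,4-difluorophenyl on a carbonyl carbon. The step that bears most directly on it is an 11-fold higher number from compound 2 to compound 3 (1.06 log units; beyond the scatter), since compound 2 also carries a methylphenyl, though a 4-methylphenyl rather than the 3-methylphenyl of compound 4; the data do not show how this placing of the methyl matters. The step of a 3.1-fold higher number from compound 1 to compound 3 (0.50 log units; beyond the scatter) points the same way, with a modest size. Run backwards, these steps suggest a lower number for compound 4, beyond the scatter, though smaller than the full return to compound 2 is not excluded either way.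

Compound 4 is therefore expected to give about 4000 nM, within 1500 nM to 12000 nM. The expected step is a 6.6-fold lower number from compound 3 to compound 4 (0.82 log units; beyond the scatter), towards a lower number.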

Compound 4, half-maximal inhibitory concentration: 13500 nM
Beside the measured number, compound 4's estimate is 3.4-fold (0.53 log units) below it, outside the stated range (above it).
By their numbers in this assay, from the lowest: compound 2; then compounds 1, 4 and 3 (each within the scatter of the next, the first and the last beyond it).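

Among these compounds, compound 4 shows that a methylphenyl on this carbonyl carbon is not enough on its own to give the low number of compound 2: with a 5.8-fold higher number from compound 2 to compound 4 (0.76 log units; beyond the scatter) beyond the scatter, the placing of the methyl counts, which the earlier compounds could not show. The other two steps are both within the scatter, a 2.0-fold lower number from compound 3 to compound 4 (0.29 log units; within the scatter) against the 2,4-difluorophenyl and a 1.6-fold higher number from compound 1 to compound 4 (0.21 log units; within the scatter) against the 4-methoxyphenyl, so in this assay the 3-methylphenyl cannot be told apart from either group. Of the four aryl groups, only the 4-methylphenyl of compound 2 now stands apart from all the others by more than the scatter, and the gain seen with it does not extend to the other methylphenyl.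

Nothing given here accounts for why the placing of the methyl matters. From the compounds shown here alone, it stays open whether an ethyl, an amine or a carboxylic acid in place of that methyl on the phenyl would keep, lose or better the number of compound 2, and whether the same order of groups would hold on any core other than the shared one.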